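This account rests on a few compounds, and the source may have more. Where it says the series, first, only, none or still open, it means among the compounds named here.

Measured so far in a functional assay on A549 cells (Homo sapiens) for cytotoxicity, read by sulforhodamine B assay, with a stated time of 2 days, tested at 100 uM; a lower number here means less inhibition, a higher number more inhibition at the concentration tested (going by the name of the read-out):
compound 1, `CCCc1n[nH]c2c(=O)n(NC(=O)c3ccncc3)c(-c3cccc(OC)c3)nc12` — 11.2%
compound 2, `CCCc1n[nH]c2c(=O)n(NC(=O)c3ccccc3)c(-c3cccc([N+](=O)[O-])c3)nc12` — 33.2%

Compound 2 stands highest of the two numbers; compound 1 is the nearest, and the gap between them lies beyond the usual scatter of this assay.

Compound 3, `CCCc1n[nH]c2c(=O)n(NC(=O)c3ccccc3)c(-c3cccc(OC)c3)nc12`, remains to be measured in this assay. Set against compound 2 the change is methoxy in place of nitro on an aromatic carbon. Compound 3 thus carries the same methoxyphenyl as compound 1, which gives 11.2%, while compound 2 gives 33.2%. Within the data shown here, the two measured compounds also differ in the amide part, so no single isolated step is available, and the two values can only be read as a loose pointer.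

The expected step of a number 15.2 percentage points lower from compound 2 to compound 3 (beyond the scatter) is downward, probably just beyond the scatter. Compound 3 is expected to give 18% in this assay, within a range of 5% to 35%.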

Compound 3, a percentage reported as inhibition, at one concentration (the size of the read-out at that concentration, not a potency): 20.7%
Compound 3: middle estimate off by 2.7 percentage points, on the low side; the range from low to high includes it.
By their numbers in this assay, from the lowest: compounds 1 and 3 (each within the scatter of the next); then compound 2.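

Among these compounds, with the amide part held fixed, the 3-nitrophenyl to 3-methoxyphenyl change gives the first isolated reading at this aromatic carbon in this assay: a number 12.5 percentage points lower from compound 2 to compound 3 (beyond the scatter). With the 3-methoxyphenyl held fixed, phenyl in place of pyridin-4-yl on the carbonyl carbon gives a number 9.5 percentage points higher from compound 1 to compound 3 (within the scatter), so this second change cannot be separated from repeat variation in these data. No measurement is available that would explain either step.

From the compounds shown here alone, how an amine or a carboxylic acid on that aromatic carbon would compare with nitro and methoxy remains open. Also open is whether the step from nitro to methoxy holds with pyridin-4-yl on the carbonyl carbon: the compounds shown carry that group only alongside methoxy.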